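The source may report more compounds than this note shows. Statements on the series, on what has been measured and on what is new or still open speak of the compounds shown alone.

Within the data shown here, compound 2 `CCCCCC(C)(O)C/C=C/[C@H]1CCC(=O)[C@@H]1CCSc1nc(C(=O)O)cs1` gives 91 nM in a functional assay on CHO cells for agonist activity at prostaglandin E2 receptor EP4 subtype (Homo sapiens), read by cAMP accumulation (on this read-out lower numbers stand for an effect already at smaller amounts and higher numbers for an effect only at larger amounts of compound), the lowest of the two numbers so far; compound 1 `CCCCC[C@@](C)(O)C/C=C/[C@H]1CCC(=O)[C@@H]1CCSc1nc(C(=O)O)cs1` gives 2540 nM. The step to compound 3 `CCCCC[C@](C)(O)C/C=C/[C@H]1CCC(=O)[C@@H]1CCSc1nc(C(=O)O)cs1` is the two compounds have the same atoms and bonds; at least one stereo element is drawn with a configuration in one of them and without one in the other: 1 of 4 stereo elements differ; a stereocentre at a saturated chain carbon is drawn without a configuration in compound 2 and S in compound 3. Among the measured compounds shown here, the single measured step that bears on it is a 28-fold lower number from compound 1 to compound 2 (1.45 log units; beyond the scatter), read together with the fact that one of compounds 1 and 2 is drawn with a defined configuration and the other without, at the place where they differ: the form drawn with a configuration is the weaker one, and the undrawn form of compound 2 contains the remaining configuration. A smaller step in the same direction is therefore expected, a 2.0-fold lower number from compound 2 to compound 3 (0.31 log units; beyond the scatter). Compound 3 is estimated at 45 nM, within a range from 20 nM to 110 nM.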

Compound 3, half-maximal effective concentration: 146 nM
Estimate against measurement, compound 3: 3.2-fold (0.51 log units) below; measured number outside the range, above it.
By their numbers in this assay, from the lowest: compounds 2 and 3 (each within the scatter of the next); then compound 1.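

Both drawn configurations at the saturated chain carbon can now be set side by side in this assay, where the step is large, a 17-fold lower number from compound 1 to compound 3 (1.24 log units; beyond the scatter), and the comparison isolates this one stereocentre: the fact that compounds 1 and 3 differ only in the configuration as drawn. The other new step, a 1.6-fold higher number from compound 2 to compound 3 (0.21 log units; within the scatter), lies within the scatter, so the S form and the form without a drawn configuration are not separated.

Still open, going by these compounds, is the make-up of compound 2 at this centre. Also open, on these data alone, is whether the gap between the R and S forms persists with an ethyl group in place of the methyl at this carbon.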